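This account rests on a few compounds, and the source may have more. Where it says the series, first, only, none or still open, it means among the compounds named here.

In a functional assay on NCI-H460 cells (Homo sapiens) for cytotoxicity, read by MTT assay, with a stated time of 72 h (on this read-out higher numbers stand for weaker inhibition and lower numbers for stronger inhibition), compound 3 `COc1cc2c(Oc3ccc(NC(=O)c4cc(-c5ccc(C(F)(F)F)cc5)ccn4)cc3F)ccnc2cc1OCCCN1CCN(C)CC1` gives 160 nM, the second highest of the three numbers measured. Compound 2 `COc1cc2c(Oc3ccc(NC(=O)c4cc(-c5ccccc5F)ccn4)cc3F)ccnc2cc1OCCCN1CCN(C)CC1` gives 140 nM, and a 1.1-fold higher number from compound 2 to compound 3 (0.06 log units; within the scatter). Compound 1 `COc1cc2c(Oc3ccc(NC(=O)c4cc(-c5ccc(F)cc5)ccn4)cc3F)ccnc2cc1OCCCN1CCN(C)CC1` gives 430 nM, and a 2.7-fold lower number from compound 1 to compound 3 (0.43 log units; beyond the scatter). Compound 4 `COc1ccc(-c2ccnc(C(=O)Nc3ccc(Oc4ccnc5cc(OCCCN6CCN(C)CC6)c(OC)cc45)c(F)c3)c2)c(OC)c1` differs from compound 3 by 2,4-dimethoxyphenyl in place of 4-(trifluoromethyl)phenyl on an aromatic carbon. Among the measured compounds shown here, no measured step involves a methoxy group, so the only steps that bear on this change are those that alter the same pendant phenyl ring: a 3.1-fold lower number from compound 1 to compound 2 (0.49 log units; beyond the scatter), a 2.7-fold lower number from compound 1 to compound 3 (0.43 log units; beyond the scatter) and a 1.1-fold higher number from compound 2 to compound 3 (0.06 log units; within the scatter). Every change at that ring so far has shifted the number only modestly or not at all, which gives no ground to expect a large move in either direction. In this assay the expected step is a 1.6-fold higher number from compound 3 to compound 4 (0.19 log units; within the scatter), small and not clearly beyond the scatter. Compound 4 is therefore estimated at 250 nM, with a range from 100 nM to 650 nM.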

Compound 4, half-maximal inhibitory concentration: 430 nM
Estimate against measurement, compound 4: 1.7-fold (0.24 log units) below; the measured number falls inside the stated range.
By their numbers in this assay, from the lowest: compounds 2 and 3 (each within the scatter of the next); then compounds 1 and 4 (each within the scatter of the next).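

In this assay, the first pendant phenyl ring with methoxy groups at this position, on the aromatic carbon opposite the ring nitrogen, gives a 2.7-fold higher number from compound 3 to compound 4 (0.43 log units; beyond the scatter) and a 3.1-fold higher number from compound 2 to compound 4 (0.49 log units; beyond the scatter), while the comparison with the 4-fluorophenyl ring shows no change at the digits printed from compound 1 to compound 4 (within the scatter). The four compounds now fall into two sets, compounds 2 and 3 in one and compounds 1 and 4 in the other, so fluorine on the ring does not by itself settle the number: compound 1 carries it yet reads with compound 4, which has none. Nothing available here accounts for this split.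

As far as these compounds go, it remains open where a ring with a single methoxy group would fall. Also open, from the compounds shown here alone, is how this assay would respond to an amine or a carboxylic acid on the ring, or to a morpholine in place of the phenyl.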